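The source may hold more compounds than are shown below. What is called first, only, known or untested is meant among the compounds shown, and "the series" means these compounds.

Measured compounds in a functional assay on HEK293 cells for activation of melanin-concentrating hormone receptor 1 (Homo sapiens), read by inositol phosphate accumulation; on this read-out higher numbers stand for an effect only at larger amounts of compound and lower numbers for an effect already at smaller amounts:
compound 1 `CCCc1cc(N2CCCC2)c2cc(NC(=O)/C=C/c3ccc(C(F)(F)F)cc3)ccc2n1`, compound 1 gives 2800 nM
compound 2 `Nc1cc(C2CCC2)nc2ccc(NC(=O)/C=C/c3ccc(C(F)(F)F)cc3)cc12`, compound 2 gives 250 nM
compound 3 `CCc1cc(N)c2cc(NC(=O)/C=C/c3ccc(C(F)(F)F)cc3)ccc2n1`, compound 3 gives 110 nM

Compound 1 stands at the highest number of the three. Compound 2 lies well below it, and compound 3 lower still; both gaps lie beyond the scatter. Going by the values given here, the only step of this kind with both ends measured is a 2.3-fold lower number from compound 2 to compound 3 (0.36 log units; beyond the scatter), a change at the alkyl group, which does not touch the place that is varied here.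

Compound 4 `CCCc1cc(N(C)C)c2cc(NC(=O)/C=C/c3ccc(C(F)(F)F)cc3)ccc2n1` differs from compound 1 in one place: dimethylamino in place of pyrrolidin-1-yl on an aromatic carbon. Among the compounds with values here, no measured pair isolates this exchange. Compound 2 and compound 3 carry a primary amino group at the same place as the pyrrolidin-1-yl of compound 1 and give far lower numbers, but they also differ from compound 1 at the alkyl group. The share of the amine in those lower numbers cannot be separated from the share of the alkyl group. Taken together, the smaller dimethylamino is expected to move compound 4 toward the values of compound 2 and compound 3, though not fully; the expected step is a 2.3-fold lower number from compound 1 to compound 4 (0.37 log units; beyond the scatter). The estimate for compound 4 in this assay is 1200 nM, with a range from 400 nM to 4000 nM.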

Compound 4, half-maximal effective concentration: 300 nM
Compound 4: the middle estimate sits 4.0-fold (0.60 log units) above what was measured; the whole stated range lies above it.
By their numbers in this assay, from the lowest: compound 3; then compounds 2 and 4 (each within the scatter of the next); then compound 1.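

In this assay, replacing pyrrolidin-1-yl with dimethylamino on the aromatic carbon opposite the ring nitrogen, with the propyl group held constant, gives a 9.3-fold lower number from compound 1 to compound 4 (0.97 log units; beyond the scatter). Going by these compounds alone, this pair shows that the read-out responds to the amine at this position alone, with no share from the alkyl group, whereas the earlier comparisons could not separate the two; the two amines match in hydrogen-bond donors, hydrogen-bond acceptors and net charge, and differ in the ring and the heavy-atom count. No measurement at hand explains the step.

Within the data shown here, a primary amino group or methylamino at this place with the propyl group kept would show how far the trend continues and would separate the share of the amine from that of the alkyl group in the earlier comparisons, while azetidin-1-yl and piperidin-1-yl would test whether the ring itself or the size of the group tracks with the higher number. From the compounds shown here alone, it also remains open whether a step of this size would hold with ethyl or cyclobutyl in place of propyl.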